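The source may report more compounds than this note shows. Statements on the series, on what has been measured and on what is new or still open speak of the compounds shown alone.

Four compounds share one core, and three of them have been tested in a functional assay on A549 cells (Homo sapiens) for cytotoxicity, read by MTT assay, with a stated time of 24 h; on this read-out higher numbers stand for weaker inhibition and lower numbers for stronger inhibition. Compound 1 `Clc1cccc(-c2nnc(C(NCc3ccccc3)c3ccc[nH]3)o2)c1` gives 62200 nM in this assay. Compound 2 `Brc1ccc(-c2nnc(C(NCc3ccccc3)c3ccc[nH]3)o2)cc1` differs from compound 1 by 4-bromophenyl in place of 3-chlorophenyl on an aromatic carbon, and in this assay compound 2 gives 87200 nM; this is a 1.4-fold higher number from compound 1 to compound 2 (0.15 log units; within the scatter). Compound 3 `Clc1cccc(-c2nnc(C(NCc3ccc(Cl)c(Cl)c3)c3ccc[nH]3)o2)c1` differs from compound 1 by 3,4-dichlorophenyl in place of phenyl on a saturated chain carbon bound to an amine nitrogen, and in this assay compound 3 gives 13300 nM, which is a 4.7-fold lower number from compound 1 to compound 3 (0.67 log units; beyond the scatter). Compound 3 thus has the lowest of the three numbers, and its steps to both other compounds lie beyond the scatter.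

Compound 4 `Clc1ccc(CNC(c2ccc[nH]2)c2nnc(-c3ccc(Br)cc3)o2)cc1Cl` has not yet been measured. It differs from compound 3 by 4-bromophenyl in place of 3-chlorophenyl on an aromatic carbon. Among the measured compounds shown here, this is the same change as the one between compound 1 and compound 2, made on a core that carries the difference described in 3,4-dichlorophenyl in place of phenyl on a saturated chain carbon bound to an amine nitrogen. That change has been seen once before and gave a 1.4-fold higher number from compound 1 to compound 2 (0.15 log units; within the scatter), a step that stays within the scatter. The step expected in this assay is a 1.4-fold higher number from compound 3 to compound 4 (0.13 log units; within the scatter), and it rests on that single earlier pair alone, so it can only be a rough guide. Compound 4 is therefore estimated to give 18000 nM in this assay, with a likely range from 8000 nM to 40000 nM.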

Compound 4, half-maximal inhibitory concentration: 17300 nM
Compound 4: middle estimate off by 1.0-fold (0.02 log units), on the high side, and the stated range covers the measured number.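

In this assay, putting 4-bromophenyl in place of 3-chlorophenyl on the dichlorinated side of the series gives a 1.3-fold higher number from compound 3 to compound 4 (0.11 log units; within the scatter), and this step matches the one seen earlier without those chlorines: the same change on two cores in this assay, a 1.4-fold higher number (0.15 log units; within the scatter) from compound 1 to compound 2 and a 1.3-fold higher number (0.11 log units; within the scatter) from compound 3 to compound 4, 1.1-fold (0.03 log units) apart, within the scatter of two such steps. The other change can now also be read on a second core, since 3,4-dichlorophenyl in place of phenyl gives a 5.0-fold lower number from compound 2 to compound 4 (0.70 log units; beyond the scatter), and it too keeps its size: the same change on two cores in this assay, a 4.7-fold lower number (0.67 log units; beyond the scatter) from compound 1 to compound 3 and a 5.0-fold lower number (0.70 log units; beyond the scatter) from compound 2 to compound 4, 1.1-fold (0.03 log units) apart, within the scatter of two such steps. So in these four compounds each change carries over from one core to the other, with the step at one place staying the same whatever the other place holds; this rests on just two cores and one cell line, however, and it does not show that the two changes would stay independent across the wider series, nor can it separate the swap of halogen from the shift in where it sits, as 3-chlorophenyl and 4-bromophenyl differ in both.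

From the compounds shown here alone, it remains open whether the same independence would hold for very different groups on the aromatic ring, such as an amine or a carboxylic acid in place of the halogens. Going by these compounds, it is equally open whether a longer chain on the amine nitrogen would leave the step from the 4-bromophenyl swap unchanged.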